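Benzothiazolyl in place of carbamoylphenyl: clearance outlook

The source may report more compounds than this note shows. Statements on the series, on what has been measured and on what is new or still open speak of the compounds shown alone.

Compound 1, `CC(C)(O)C#Cc1cc(C(O)(C(F)(F)F)C(F)(F)F)cnc1N1CCN(S(=O)(=O)c2ccc(N)nc2)CC1`: 16 mL.min-1.g-1
Compound 2, `Nc1ccc(S(=O)(=O)N2CCN(c3ncc(C(O)(C(F)(F)F)C(F)(F)F)cc3C#CCCO)CC2)cn1`: 68 mL.min-1.g-1
Compound 3, `NC(=O)c1cccc(-c2cc(C(O)(C(F)(F)F)C(F)(F)F)cnc2N2CCN(S(=O)(=O)c3ccc(N)nc3)CC2)c1`: 63 mL.min-1.g-1

In an ADME assay (liver) for metabolic stability, with Liver microsome (Rattus norvegicus) as the target, using microsomes and NADPH, with a stated time of 30 min, tested at 1 uM (a higher number here means faster removal of the compound, a lower number slower removal), compound 3 gives 63 mL.min-1.g-1, the second highest of the three numbers. Its nearest neighbour is compound 2, and the step of a 1.1-fold lower number from compound 2 to compound 3 (0.03 log units; within the scatter) lies within the scatter. Its furthest neighbour is compound 1, separated by the step of a 3.9-fold higher number from compound 1 to compound 3 (0.60 log units; beyond the scatter), which is beyond the scatter.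

Compound 4, `Nc1ccc(S(=O)(=O)N2CCN(c3ncc(C(O)(C(F)(F)F)C(F)(F)F)cc3-c3ccc4scnc4c3)CC2)cn1`, differs from compound 3 in one place: 1,3-benzothiazol-5-yl in place of 3-carbamoylphenyl on an aromatic carbon.

Among the compounds with values here, no measured step makes this exact exchange. The two steps beyond the scatter, a 4.3-fold higher number from compound 1 to compound 2 (0.63 log units; beyond the scatter) and a 3.9-fold higher number from compound 1 to compound 3 (0.60 log units; beyond the scatter), both start from compound 1 and remove its 3-hydroxy-3-methylbut-1-yn-1-yl group, so they do not speak to replacing 3-carbamoylphenyl. Within the data shown here, the one step that ends at compound 3, a 1.1-fold lower number from compound 2 to compound 3 (0.03 log units; within the scatter), stayed within the scatter even though the group on that aromatic carbon changed a great deal. On this basis the expected step of a 1.2-fold higher number from compound 3 to compound 4 (0.08 log units; within the scatter) is within the scatter, with no direction favoured. Compound 4 is therefore estimated to give 75 mL.min-1.g-1 in this assay, within a range of 30 mL.min-1.g-1 to 190 mL.min-1.g-1.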

Compound 4, intrinsic clearance in microsomes: 147 mL.min-1.g-1
For compound 4 the middle estimate is 2.0-fold (0.29 log units) below the measured one; the measured number falls inside the stated range.
By their numbers in this assay, from the lowest: compound 1; then compounds 3 and 2 (each within the scatter of the next); then compound 4.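

In this assay the aromatic carbon ortho to a large group now shows that an exchange between two aromatic groups can move the number beyond the scatter: 1,3-benzothiazol-5-yl in place of 3-carbamoylphenyl gives (a 2.3-fold higher number from compound 3 to compound 4 (0.37 log units; beyond the scatter)), whereas the earlier exchange of 4-hydroxybut-1-yn-1-yl for 3-carbamoylphenyl stayed within it. The 1,3-benzothiazol-5-yl group also lies beyond the scatter from both hydroxy-bearing alkynyl groups (a 2.2-fold higher number from compound 2 to compound 4 (0.33 log units; beyond the scatter)) and (a 9.2-fold higher number from compound 1 to compound 4 (0.96 log units; beyond the scatter)), so compound 4 has the highest number of the four, and a second aromatic group at this carbon does not simply match compound 3. Nothing measured here explains why this exchange raises the number.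

The compounds shown leave open whether the rise follows from the loss of the carbamoyl group or from the entry of the fused sulfur-containing ring. A plain phenyl group, or a phenyl group carrying a carboxylic acid or an amine at the same ring position as the carbamoyl group, would help to separate these two readings.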